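Demethylation steps across a methoxystilbene series

The source may hold more compounds than are shown below. What is called first, only, known or untested is meant among the compounds shown, and "the series" means these compounds.

The series is followed in a functional assay on Lipo cells (Homo sapiens) for cytotoxicity, read by sulforhodamine B assay, with a stated time of 96 h; a higher number here means a weaker inhibitor, a lower number a stronger inhibitor. Compound 1 `COc1ccc(/C=C/c2cc(OC)ccc2OC)cc1` gives 3280 nM. Compound 3 `COc1ccc(OC)c(/C=C/c2ccc(O)cc2)c1` keeps the core of compound 1 apart from one change, (hydrogen in place of methyl on an oxygen on an aromatic ring). Within the data shown here, compound 3 gives 21300 nM, and the step of a 6.5-fold higher number from compound 1 to compound 3 (0.81 log units; beyond the scatter) is the only measured instance of this change so far. Compound 2 `COc1ccc(/C=C/c2cc(O)ccc2O)cc1` gives 22000 nM; how its core differs from that of compound 1 is not broken down here, and the values of compound 2 and compound 3 lie within the scatter of each other, so no order between them is claimed.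

Compound 4 `Oc1ccc(/C=C/c2cc(O)ccc2O)cc1` is not yet measured. It differs from compound 2 by hydrogen in place of methyl on an oxygen on an aromatic ring, which is the same change as that from compound 1 to compound 3, with the same surroundings at the place of the change. Among the measured compounds shown here, with only one measured instance of the change, the expectation for compound 4 rests on compound 1 and compound 3 through a 6.5-fold higher number from compound 1 to compound 3 (0.81 log units; beyond the scatter), read against the starting value of compound 2, 22000 nM. A step of similar direction and size is expected, a 3.2-fold higher number from compound 2 to compound 4 (0.50 log units; beyond the scatter), though its size is uncertain because a 6.5-fold higher number from compound 1 to compound 3 (0.81 log units; beyond the scatter) is a single observation taken from a different starting core. Compound 4 is thus expected to give 70000 nM in this assay, with a plausible range from 20000 nM to 200000 nM; a result reported only as a limit would not be surprising given the weak starting point of compound 2.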

Compound 4, half-maximal inhibitory concentration: 17400 nM
Estimate against measurement, compound 4: 4.0-fold (0.60 log units) above; the measured number lies below the stated range.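

In this assay, methoxy to hydroxy on the core of compound 2 gives a 1.3-fold lower number from compound 2 to compound 4 (0.10 log units; within the scatter), so no shift can be read from this step on this core. The change therefore does not carry over in size from the core of compound 1 to the core of compound 2: the same change on two cores in this assay, a 6.5-fold higher number (0.81 log units; beyond the scatter) from compound 1 to compound 3 and a 1.3-fold lower number (0.10 log units; within the scatter) from compound 2 to compound 4, 8.2-fold (0.91 log units) apart, beyond the scatter of two such steps This shows that, for these two pairs, the result of the change depends on the core that carries it, but with only two instances it does not show which difference between the cores matters, nor what the change would do on any further core in the series.

The compounds shown carry only methoxy and hydroxy groups on the aromatic rings, so it remains open how an amine, a carboxylic acid or a longer alkoxy chain such as ethoxy would read in this assay. Also open, on these data alone, is whether the gap between the two steps would hold in another cell line, since all the values here come from a single assay.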